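A few compounds are considered here, and "the series" means these few. Any claim that something is new, unique, unknown or untested is made for them only; others in the source may bear on it.

Among the measured compounds shown here, compound 3 `O=C(CN(C(=O)C1CCOCC1)C1CCCCC1)Nc1cc(F)cc(F)c1` is the only member of the set with a number rather than a limit in an assay on HEK293 cells for inhibition of sodium- and chloride-dependent glycine transporter 1 (Homo sapiens), read by scintillation proximity assay; on this read-out higher numbers stand for weaker inhibition and lower numbers for stronger inhibition: compound 3 gives 5010 nM. Compound 1 `O=C(CN(Cc1ccc(Cl)cc1)C1CCCCC1)Nc1cc(F)cc(F)c1` in this assay gives only a limit, > 25100 nM. Compound 2 `CN1CCC(C(=O)N(CC(=O)Nc2cc(F)cc(F)c2)C2CCCCC2)CC1` likewise gives only a limit, > 25100 nM, which is the limit of > 25100 nM in this assay, at which 2 of the 3 values shown sit. Compound 4 `O=C(CN(C(=O)C1CCCCC1)C1CCCCC1)Nc1cc(F)cc(F)c1` differs from compound 3 by cyclohexyl in place of oxan-4-yl on a carbonyl carbon. The nearest measured step is an at least 5.0-fold lower number from compound 2 to compound 3 (0.69 log units; beyond the scatter), which exchanges one six-membered non-aromatic ring for another on the same carbonyl carbon; an at least 5.0-fold lower number from compound 1 to compound 3 (0.69 log units; beyond the scatter) concerns a different position. Neither step covers loss of the ring oxygen, so the direction is open and a modest change in either sense is plausible. Compound 4 is expected at 3200 nM, within 800 nM to 12000 nM, an estimated 1.6-fold lower number from compound 3 to compound 4 (0.19 log units; within the scatter).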

Compound 4, half-maximal inhibitory concentration: 6310 nM
Compound 4: middle estimate off by 2.0-fold (0.29 log units), on the low side; the measured number falls inside the stated range.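

Loss of the ring oxygen costs nothing readable on this carbonyl carbon: a 1.3-fold higher number from compound 3 to compound 4 (0.10 log units; within the scatter) stays within the scatter, so oxan-4-yl and cyclohexyl are not told apart here. Cyclohexyl keeps the same side as oxan-4-yl against the other two groups, with an at least 3.9-fold lower number from compound 2 to compound 4 (0.59 log units; beyond the scatter) and an at least 3.9-fold lower number from compound 1 to compound 4 (0.59 log units; beyond the scatter) in the series. Both of these sizes are only bounds, since compound 1 and compound 2 give limits: the limit of > 25100 nM in this assay, at which 2 of the 4 values shown sit.

Open, as far as these compounds go, is whether a phenyl ring, a longer alkyl chain or a cyclohexyl ring bearing a carboxylic acid on this carbonyl carbon moves the number beyond the scatter. Also open, from the compounds shown here alone, is whether any such group reaches far lower numbers than the cyclohexyl and oxan-4-yl pair.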